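The compounds below may be only part of what the source reports. "The series", "measured", "known", "first", "only" and "open" are said of these compounds alone.

Compound 1: `COc1cc2c(Oc3ccc(NC(=O)c4nn(-c5ccccc5F)c(=O)c5ccccc45)cc3F)ccnc2cc1OCCCN1CCCC1` — 140 nM
Compound 2: `COc1cc2c(Oc3ccc(NC(=O)c4nn(-c5ccccc5)c(=O)c5ccccc45)cc3F)ccnc2cc1OCCCN1CCN(C)CC1` — 620 nM
Compound 3: `COc1cc2c(Oc3ccc(NC(=O)c4nn(-c5ccc(F)cc5)c(=O)c5ccccc45)cc3F)ccnc2cc1OCCCN1CCN(C)CC1` — 150 nM

Three compounds share a common core and were tested in a functional assay on MKN-45 cells (Homo sapiens) for cytotoxicity, read by MTT assay, with a stated time of 72 h; a higher number here means a weaker inhibitor, a lower number a stronger inhibitor. Compound 3 gives 150 nM, the second highest of the three numbers: its nearest neighbour is compound 1, which gives 140 nM, a gap within the usual scatter, while compound 2, which gives 620 nM, lies furthest away, beyond the scatter. Going by the values given here, the one single-point step measured so far is a 4.1-fold lower number from compound 2 to compound 3 (0.62 log units; beyond the scatter), a modest change.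

Compound 4, `COc1cc2c(Oc3ccc(NC(=O)c4nn(-c5ccccc5F)c(=O)c5ccccc45)cc3F)ccnc2cc1OCCCN1CCN(C)CC1`, is not yet measured. It differs from compound 3 by 2-fluorophenyl in place of 4-fluorophenyl on an aromatic nitrogen. Among the compounds with values here, no measured step describes this exact swap. Compound 1 carries the same 2-fluorophenyl group together with a different chain, and its value sits within the scatter of compound 3, which suggests the fluorine's placement on the phenyl ring has little visible effect here. A step of no change at the digits printed from compound 3 to compound 4 (within the scatter) is therefore expected, essentially none beyond the scatter. The estimate for compound 4 in this assay is 150 nM, with a range from 60 nM to 400 nM.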

Compound 4, half-maximal inhibitory concentration: 210 nM
Compound 4: middle estimate off by 1.4-fold (0.15 log units), on the low side; the range from low to high includes it.
By their numbers in this assay, from the lowest: compounds 1, 3 and 4 (each within the scatter of the next); then compound 2.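

In this assay, 2-fluorophenyl in place of 4-fluorophenyl on the aromatic nitrogen gives a 1.4-fold higher number from compound 3 to compound 4 (0.15 log units; within the scatter) and so leaves the two fluorine placements indistinguishable with the 4-methylpiperazin-1-yl group held constant. Adding fluoro to the plain phenyl ring gives a 3.0-fold lower number from compound 2 to compound 4 (0.47 log units; beyond the scatter) here and a 4.1-fold lower number from compound 2 to compound 3 (0.62 log units; beyond the scatter) in the earlier step, so both fluorinated compounds stand apart from the compound without fluorine by more than the scatter. The chain end can also change without a clear effect, as 4-methylpiperazin-1-yl in place of pyrrolidin-1-yl gives a 1.5-fold higher number from compound 1 to compound 4 (0.18 log units; within the scatter) for compounds that both carry 2-fluorophenyl.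

As far as these compounds go, whether a chlorine atom or a methoxy group on the phenyl ring would behave like fluorine stays open, as does how a morpholine at the chain end would compare. Nothing measured here gives a reason for these steps.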